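Replacing Benzyl with 3-Methoxyphenyl at the Ether Oxygen

This account rests on a few compounds, and the source may have more. Where it says the series, first, only, none or still open, it means among the compounds named here.

Compound 1, `N[C@]1(CO)CC[C@H](c2ccc3c(c2)CC[C@H](COCc2ccccc2)C3)C1`: 0%
Compound 2, `COc1ccc(COC[C@@H]2CCc3cc([C@H]4CC[C@](N)(CO)C4)ccc3C2)cc1`: 33%
Compound 3, `N[C@]1(CO)CC[C@H](c2ccc3c(c2)CC[C@@H](COCc2ccccc2)C3)C1`: 49%

In a functional assay on the whole organism (strain Lewis) with Rattus norvegicus as the target, with a stated time of 24 h, at a dose of 0.3 mg/kg by the oral route (a lower number here means less inhibition, a higher number more inhibition at the dose given (going by the name of the read-out)), compound 3 stands highest of the three measured compounds. The gap to compound 1 is large, a number 49 percentage points higher from compound 1 to compound 3 (beyond the scatter), and it is traced to the fact that compounds 1 and 3 differ only in the configuration as drawn. The gap to compound 2 is smaller, a number 16 percentage points higher from compound 2 to compound 3 (beyond the scatter), and comes from hydrogen in place of methoxy on an aromatic carbon.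

Compound 4 `COc1cccc(OC[C@@H]2CCc3cc([C@H]4CC[C@](N)(CO)C4)ccc3C2)c1` differs from compound 3 by 3-methoxyphenyl in place of benzyl on an oxygen on a saturated carbon. Among the measured compounds shown here, no measured step alters this part of the molecule directly; the nearest evidence is the modest methoxy step between compound 2 and compound 3. For compound 4 a modest decrease is therefore expected, a number 14 percentage points lower from compound 3 to compound 4 (beyond the scatter), possibly within the scatter. Compound 4 is estimated at 35%, between 10% and 60%.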

Compound 4, a percentage reported as inhibition, in the whole organism at one dose (the size of the read-out at that dose, not a potency): 80%
Beside the measured number, compound 4's estimate is 45 percentage points below it; the measured number lies above the stated range.
By their numbers in this assay, from the lowest: compound 1; then compound 2; then compound 3; then compound 4.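

The group on the ether oxygen carries more weight in this assay than the earlier methoxy step suggested, with the change from benzyl to 3-methoxyphenyl giving a number 31 percentage points higher from compound 3 to compound 4 (beyond the scatter). Replacing 4-methoxybenzyl with 3-methoxyphenyl gives a number 47 percentage points higher from compound 2 to compound 4 (beyond the scatter), so a methoxy group on the aromatic ring does not go with a lower number in every case here. Nothing at hand bears on why this change acts as it does.

Still open, from the compounds shown here alone, is whether the gain follows from the methoxy group or from the loss of the benzyl carbon. A plain phenyl on this oxygen would separate the two.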